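Lengthening the alkoxy chain on a shared core

The source may report more compounds than this note shows. Statements on the series, on what has been measured and on what is new or still open speak of the compounds shown alone.

Two compounds set the scene. Compound 1 `CCCCc1ccc(-c2c(CC)[nH]c(=O)n2C)cc1` and compound 2 `CCCCOc1ccc(-c2c(C)[nH]c(=O)n2C2CCCCC2)cc1` share a core and differ in several places at once, so their structures stand beside them rather than being compared piece by piece. In a functional assay on brain (Rattus norvegicus, strain Wistar) for inhibition (on this read-out lower numbers stand for stronger inhibition and higher numbers for weaker inhibition), compound 1 gives 13900 nM. In this assay compound 2 gives 13900 nM, level with compound 1 within the scatter, so the two cannot be placed in order. Compound 3 `CCCCCCCCOc1ccc(-c2c(C)[nH]c(=O)n2C2CCCCC2)cc1` is built from compound 2 by one change: butyl in place of hydrogen on a saturated chain carbon, four bonds along the chain from an oxygen on an aromatic ring. Going by the values given here, no measured pair shows what such a lengthening does here, so the expectation rests on compound 2 alone. The step of a 1.4-fold lower number from compound 2 to compound 3 (0.14 log units; within the scatter) is expected to be small, with only a slight lean toward stronger inhibition. Compound 3 is therefore estimated to give 10000 nM in this assay, with a likely range from 3000 nM to 40000 nM.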

Compound 3, half-maximal inhibitory concentration: 8500 nM
For compound 3 the middle estimate is 1.2-fold (0.07 log units) above the measured one; measured number inside the range.
By their numbers in this assay, from the lowest: compounds 3, 1 and 2 (each within the scatter of the next).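

At this place, on a saturated chain carbon, four bonds along the chain from an oxygen on an aromatic ring, butyl in place of hydrogen gives a 1.6-fold lower number from compound 2 to compound 3 (0.21 log units; within the scatter) in this assay. Going by these compounds alone, this is the first direct reading of such a lengthening on this core: adding 4 carbon atoms, with no ring, no hydrogen-bond donor or acceptor and no net charge, leaves compound 2 and compound 3 indistinguishable in this measurement. No supporting measurement is available to explain this outcome.

A single step cannot show whether a longer chain would likewise leave the reading within the scatter. It also leaves open what an amine or a carboxylic acid would do at this same place on the chain.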